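A few compounds are considered here, and "the series" means these few. Any claim that something is new, unique, unknown or untested is made for them only; others in the source may bear on it.

Working notes on the series. Compound 1 `O=C(Nc1cccnc1)c1ccccc1OCc1ccccc1` gives 3200 nM in an assay on lysate for inhibition of phosphatidylcholine:ceramide cholinephosphotransferase 2 (Homo sapiens), read by HPLC, with stated times of 30 min and 2 h; on this read-out lower numbers stand for stronger inhibition and higher numbers for weaker inhibition. Compound 2 `O=C(Nc1cccnc1)c1ccccc1OCc1cccc(Cl)c1` gives 1400 nM in this assay, and compound 3 `O=C(Nc1cccnc1)c1ccccc1OCc1c(Cl)cccc1Cl` gives 690 nM in this assay. Compound 2 stands second highest of the three numbers: the nearest is compound 3, reached through a 2.0-fold lower number from compound 2 to compound 3 (0.31 log units; beyond the scatter), and the furthest is compound 1, from which a 2.3-fold lower number from compound 1 to compound 2 (0.36 log units; beyond the scatter). The full span of the set is a 4.6-fold lower number from compound 1 to compound 3 (0.67 log units; beyond the scatter).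

Compound 4 `COCCOc1ccc(Cl)cc1COc1ccccc1C(=O)Nc1cccnc1` has not been measured. It differs from compound 2 by 2-methoxyethoxy in place of hydrogen on an aromatic carbon. Within the data shown here, no measured step introduces a 2-methoxyethoxy group, or any oxygen-containing group, on this ring; all three measured steps concern chloro on the same ring, and each was modest: a 2.3-fold lower number from compound 1 to compound 2 (0.36 log units; beyond the scatter), a 2.0-fold lower number from compound 2 to compound 3 (0.31 log units; beyond the scatter) and a 4.6-fold lower number from compound 1 to compound 3 (0.67 log units; beyond the scatter). They show that substitution on this ring has so far lowered the number modestly, but they carry no information on a group of this kind. The expectation for compound 4 in this assay is therefore a step of no more than modest size from compound 2, in either direction, most likely within the scatter. The estimate for compound 4 is 1100 nM, with a range from 350 nM to 3500 nM. For compound 4 this means an expected step of a 1.3-fold lower number from compound 2 to compound 4 (0.10 log units; within the scatter).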

Compound 4, half-maximal inhibitory concentration: 11600 nM
Compound 4: the middle estimate sits 11-fold (1.02 log units) below what was measured; measured number outside the range, above it.
By their numbers in this assay, from the lowest: compound 3; then compound 2; then compound 1; then compound 4.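

In this assay, 2-methoxyethoxy in place of hydrogen, on the aromatic carbon ortho to a large group and para to a chloro group, gives an 8.3-fold higher number from compound 2 to compound 4 (0.92 log units; beyond the scatter). This runs against the direction of the chloro changes on the same ring, a 2.3-fold lower number from compound 1 to compound 2 (0.36 log units; beyond the scatter) and a 2.0-fold lower number from compound 2 to compound 3 (0.31 log units; beyond the scatter), so substitution on this ring does not move the number one way, and the trend seen with chloro does not carry over to a 2-methoxyethoxy group at this carbon. Nothing available bears on why the number rises with this group.

The compounds shown leave open whether the rise belongs to this carbon as such or to the group placed on it, since a single methoxy group, a hydroxyl group or a fluoro group at the same carbon does not appear among them. They also leave open how the number depends on the chain itself, as a longer ether chain, or a chain ending in an amine or a carboxylic acid, does not appear in the set, and 2-methoxyethoxy is seen only alongside the chloro group of compound 4.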